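Swapping the benzamide for a small lactam

The source may hold more compounds than are shown below. What is called first, only, known or untested is meant among the compounds shown, and "the series" means these compounds.

Three compounds share a core and differ at one position. Compound 1 `O=C(Nc1cnc(NCc2c(F)ccc3c2CCO3)n2cnnc12)c1ccccc1` carries the benzamido group. In a physicochemical assay for lipophilicity, using the shake flask method, in phosphate buffer, measured as octanol-water partition, with a stated time of 30 min, at pH 7.4 (a lower number here means a more polar compound, a higher number a more lipophilic compound), compound 1 gives 3, the highest of the three numbers seen so far. Compound 2 `Cc1nc(CN(C)C)ccc1-c1cnc(NCc2c(F)ccc3c2CCO3)c2cn[nH]c(=O)c12` gives 2 in this assay, a number lower than that of compound 1 by more than the scatter. For the measured compounds named here, compound 3 `CN(C)Cc1ccc(C(=O)Nc2cnc(NCc3c(F)ccc4c3CCO4)n3cnnc23)cc1` gives 1.8, and the step of a number 1.20 log units lower from compound 1 to compound 3 (beyond the scatter) is the only single-point change with a measurement: it shows a large drop for (dimethylamino)methyl in place of hydrogen on an aromatic carbon.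

Compound 4 `C[C@H]1CC(=O)N(c2cnc(NCc3c(F)ccc4c3CCO4)n3cnnc23)C1` is the next step from compound 1. The change is 4-methyl-2-oxopyrrolidin-1-yl in place of benzamido on an aromatic carbon. The benzamido group that leaves brings a hydrogen-bond donor and a six-membered aromatic ring; the 4-methyl-2-oxopyrrolidin-1-yl that enters has no donor, fewer heavy atoms and a non-aromatic five-membered ring.

Going by the values given here, no measured step covers this exact change, and the drop seen from compound 1 to compound 3 concerns a different group, so it only marks how far this position can move the number. Compound 4 is expected to come out lower than compound 1, by an estimated a number 1.00 log units lower from compound 1 to compound 4 (beyond the scatter). The estimate for compound 4 in this assay is 2, within a range from 1.3 to 2.7.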

Compound 4, distribution coefficient: 1.8
For compound 4 the middle estimate is 0.20 log units above the measured one; low and high end bracket the measured number.
By their numbers in this assay, from the lowest: compounds 3, 4 and 2 (each within the scatter of the next); then compound 1.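

Replacing benzamido with 4-methyl-2-oxopyrrolidin-1-yl gives a large step in this assay, a number 1.20 log units lower from compound 1 to compound 4 (beyond the scatter), so the number at this position also moves when the six-membered aromatic ring and the amide hydrogen leave together, and not only when a group is added to that ring. Two very different changes at this position end within the scatter of each other: compound 3, which keeps the benzamido unit and adds (dimethylamino)methyl, gives 1.8, and compound 4, which has no aromatic ring in this group, gives 1.8. This single step changes the ring, the amide hydrogen and the heavy-atom count all at once, and no measurement here explains the step or divides it among those changes.

Going by these compounds, it remains open how much of the step belongs to the methyl group and its defined stereocentre, which a plain 2-oxopyrrolidin-1-yl group or the opposite stereoisomer of compound 4 could help to separate. Also open, on these data alone, is how the number would respond to an amine or a carboxylic acid attached to the five-membered ring of compound 4.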